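The source may hold more compounds than are shown below. What is called first, only, known or untested is meant among the compounds shown, and "the series" means these compounds.

In a functional assay on MCF7 cells (Homo sapiens) for cytotoxicity, read by MTT assay, with a stated time of 48 h (on this read-out lower numbers stand for stronger inhibition and higher numbers for weaker inhibition), compound 1 `CCN(CC)C(=S)SC(CC(=O)c1ccccc1)c1ccc(Cl)cc1` gives 120 nM and compound 2 `CCN(CC)C(=S)SC(CC(C)=O)c1ccccc1` gives 23000 nM on the same read-out. For the measured compounds named here, compound 2 therefore holds the higher of only two numbers, and the gap between them lies beyond the usual scatter of repeated measurements. The two compounds differ in more than one place, so the gap cannot be pinned on any single change. Compound 3 `CCN(CC)C(=S)SC(CC(=O)c1ccc(Cl)c(Cl)c1)c1ccccc1` starts from compound 2 and puts 3,4-dichlorophenyl in place of methyl on a carbonyl carbon, a change counted as 3,4-dichlorophenyl in place of methyl on a carbonyl carbon in this comparison. Going by the values given here, no measured pair isolates this change, so the forecast leans on one comparison: compound 1 also has an aromatic ring on its carbonyl carbon, and compound 1 gives 120 nM in this assay as its result. A large fall, well beyond the scatter, is therefore expected, and the estimated step of a 77-fold lower number from compound 2 to compound 3 (1.88 log units; beyond the scatter) points towards stronger inhibition. For compound 3 the expected value is 300 nM with an estimated range from 50 nM to 2500 nM as the likely span.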

Compound 3, half-maximal inhibitory concentration: 4500 nM
Beside the measured number, compound 3's estimate is 15-fold (1.18 log units) below it; the whole stated range lies below it.
By their numbers in this assay, from the lowest: compound 1; then compound 3; then compound 2.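

In this assay, for the compounds shown here, putting 3,4-dichlorophenyl in place of methyl on a carbonyl carbon gives a 5.1-fold lower number from compound 2 to compound 3 (0.71 log units; beyond the scatter) as the only comparison so far that changes a single place. This shows that a carbonyl carbon whose other neighbour is a saturated chain carbon can carry a six-membered aromatic ring instead of a lone methyl, and that inhibition in this read-out becomes modestly stronger rather than being lost. The same step also shows that this one change is far from enough to span the whole gap first seen between the two earlier compounds, yet no information at hand explains why the number moves at all.

The compounds shown leave open whether the ring itself or its two chlorine atoms carries the step, a question that a plain phenyl on the same carbonyl carbon, with everything else as in compound 2, would help to settle. Going by these compounds, it also remains open how a longer alkyl chain or a ring bearing an amine would behave at this same place.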